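Chlorinated dihydropyran series: ring-carbon substituent swap

The compounds below may be only part of what the source reports. "The series", "measured", "known", "first", "only" and "open" are said of these compounds alone.

Measured compounds:
Compound 1 `C[C@H]1CC(Cl)=C([Si](C)(C)C)[C@@H](C2CCCCC2)O1`: 74000 nM
Compound 2 `CC[C@H]1CC(Cl)=C([Si](C)(C)C)[C@@H](C2CCCCC2)O1`: 95000 nM

Both values come from a functional assay on WiDr cells (Homo sapiens) for antiproliferative activity; on this read-out higher numbers stand for lower toxicity in this test and lower numbers for higher toxicity in this test. Within the data shown here, compound 2 gives the highest of the two numbers; the nearest is compound 1, and the step of a 1.3-fold higher number from compound 1 to compound 2 (0.11 log units; within the scatter) is the only measured step in the set. On the two numbers shown, compound 2 therefore stands within the scatter of compound 1, and no order between them can be claimed.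

Compound 3 `C[Si](C)(C)C1=C(Cl)C[C@H](C2CCCCC2)O[C@@H]1C1CCCCC1` differs from compound 2 by cyclohexyl in place of ethyl on a saturated ring carbon. Among the measured compounds shown here, no measured pair carries this change, and the one step available, which enlarges the group on a saturated chain carbon bound to a saturated ring carbon, was within the scatter. The data give no basis for expecting a move beyond the scatter in this assay for compound 3; the replacement is larger than the measured one, so the range is kept wide.

The expected step is a 1.1-fold lower number from compound 2 to compound 3 (0.05 log units; within the scatter). Compound 3 is estimated at 85000 nM, with a range from 30000 nM to 240000 nM.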

Compound 3, concentration lethal to 50% of the cells: 97000 nM
The estimate for compound 3 lay 1.1-fold (0.06 log units) below the measured number; the measured number falls inside the stated range.
By their numbers in this assay, from the lowest: compounds 1, 2 and 3 (each within the scatter of the next).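

In this assay, cyclohexyl on the saturated ring carbon next to the ring oxygen gives a 1.0-fold higher number from compound 2 to compound 3 (0.01 log units; within the scatter) and, set against methyl at the same place, a 1.3-fold higher number from compound 1 to compound 3 (0.12 log units; within the scatter), so both steps lie within the scatter. This position therefore takes a group of 6 heavy atoms with one six-membered non-aromatic ring of carbon only, in place of the 2 heavy atoms of ethyl, without any readable change in this read-out, and methyl, ethyl and cyclohexyl cannot be put in an order here. Nothing on hand explains why the three numbers stay together.

As far as these compounds go, whether an amine, a carboxylic acid or a phenyl ring on this saturated ring carbon would move the number beyond the scatter remains open, as all three groups seen here are saturated carbon groups with no hydrogen-bond donors or acceptors. From the compounds shown here alone, the three compounds also share the chloro group, the other cyclohexyl group and the group of 4 heavy atoms, so the effect of replacing any of these, for example chloro by bromo or hydroxyl, is equally open in this assay.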